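Azidomethyl in place of the amidoxime-type group on the shared core

A few compounds are considered here, and "the series" means these few. Any claim that something is new, unique, unknown or untested is made for them only; others in the source may bear on it.

Measured so far in a toxicity assay on CCRF-CEM cells (Homo sapiens) for cytotoxicity; a higher number here means that more compound is tolerated, a lower number that less compound is tolerated:
compound 1 `Oc1cccc2c1nc(-c1c(F)cccc1F)n2Cc1c(F)cccc1F` gives > 100 uM
compound 2 `CN(C)c1cccc2c1nc(-c1c(F)cccc1F)n2Cc1c(F)cccc1F` gives > 100 uM
compound 3 `N=C(NO)c1cccc2c1nc(-c1c(F)cccc1F)n2Cc1c(F)cccc1F` gives 23.1 uM

The value of compound 1 is a limit of this assay, not a number. The value of compound 2 is likewise a limit. Among the compounds with values here, compound 3 is the only compound of the three with a measured number, and it stands below both limits: an at least 4.3-fold lower number from compound 1 to compound 3 (0.63 log units; beyond the scatter) and an at least 4.3-fold lower number from compound 2 to compound 3 (0.63 log units; beyond the scatter). The step from hydroxy to dimethylamino, a step that the two limits leave unreadable from compound 1 to compound 2, cannot be read, because the limit of > 100 uM in this assay, at which 2 of the 3 values shown sit, hides both ends.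

Compound 4 `[N-]=[N+]=NCc1cccc2c1nc(-c1c(F)cccc1F)n2Cc1c(F)cccc1F` differs from compound 3 in one place: a group of 4 heavy atoms (1 carbon, 3 nitrogen; no ring) in place of a group of 4 heavy atoms (1 carbon, 2 nitrogen, 1 oxygen; no ring), on an aromatic carbon. Within the data shown here, no measured step replaces this group directly, so the two steps into compound 3 are the only guide. Both show that putting the group of 4 heavy atoms with 1 carbon, 2 nitrogen and 1 oxygen onto the core gave a lower number than the hydroxy or dimethylamino it replaced. Taking that group away again and putting azidomethyl in its place is therefore expected to move this assay back up, toward the limit where compound 1 and compound 2 sit, though the azidomethyl group itself has no precedent here.

For compound 4 the estimate is 60 uM, within 20 uM to 150 uM, an expected step of a 2.6-fold higher number from compound 3 to compound 4 (0.41 log units; beyond the scatter).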

Compound 4, half-maximal toxic concentration: > 100 uM
Compound 4: no number, only a limit; the forecaster's own chance of this, stated with the estimate: 40%; middle value at least 1.6-fold (0.22 log units) from the limit.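

In this assay, azidomethyl in place of the group with 1 carbon, 2 nitrogen and 1 oxygen gives an at least 4.3-fold higher number from compound 3 to compound 4 (0.63 log units; beyond the scatter), and since both groups hold 4 heavy atoms and no ring, the count of heavy atoms at this aromatic carbon does not separate the measured number from the limit. Compound 4 gives > 100 uM, which is a limit of this assay and not a number. Within the data shown here, compound 3 remains the only one of the four compounds with a measured number, and the steps from compound 1 and from compound 2 to compound 4 cannot be read: the limit of > 100 uM in this assay, at which 3 of the 4 values shown sit.

The compounds shown leave open which part of the group in compound 3 goes with the lower number, and how far compound 1, compound 2 and compound 4 differ from one another. Among these compounds, an aminomethyl group, a carboxylic acid or a longer chain on this aromatic carbon could show whether any group other than the one in compound 3 also gives a number in this assay.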